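The compounds below may be only part of what the source reports. "The series", "measured", "known", "first", "only" and "open" are said of these compounds alone.

Going by the values given here, in a physicochemical assay for lipophilicity, at pH 7.4 (on this read-out lower numbers stand for lower lipophilicity and higher numbers for higher lipophilicity), compound 2 `CNC(=O)c1cc(C(=O)N[C@H]2[C@@H]3COC[C@@H]32)cc2c1OC[C@H]2C1CCOCC1` gives 2.1, the lower of the two numbers so far, while compound 1 `CNC(=O)c1cc(C(=O)N[C@H]2[C@@H]3COC[C@@H]32)cc2c1OC[C@H]2c1cccc(OC)c1` gives 3.2. Compound 3 `CNC(=O)c1cc(C(=O)N[C@H]2[C@@H]3COC[C@@H]32)cc2c1OC[C@H]2c1ccccc1C` carries 2-methylphenyl in place of oxan-4-yl on a saturated ring carbon. Among the compounds with values here, the one measured step that bears on this is a number 1.10 log units lower from compound 1 to compound 2 (beyond the scatter), a large step with oxan-4-yl in place of 3-methoxyphenyl. The new change runs the opposite way, from oxan-4-yl back to a phenyl group, so a large upward step is expected, a number 1.20 log units higher from compound 2 to compound 3 (beyond the scatter). The estimate for compound 3 is 3.3, with the expected range running from 2.9 to 3.7.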

Compound 3, distribution coefficient: 4
Compound 3: the middle estimate sits 0.70 log units below what was measured, outside the stated range (above it).
By their numbers in this assay, from the lowest: compound 2; then compound 1; then compound 3.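

In this assay, the change at this saturated ring carbon gives a large rise, a number 1.90 log units higher from compound 2 to compound 3 (beyond the scatter). The choice of aromatic group matters too: 2-methylphenyl in place of 3-methoxyphenyl gives a number 0.80 log units higher from compound 1 to compound 3 (beyond the scatter), so having a phenyl ring here does not alone set the number. Nothing available explains either step.

These two aromatic groups differ in both substituent and its place on the ring, so those two changes cannot be separated. On these data alone, how an unsubstituted phenyl, or an oxan-4-yl replaced by a piperidine amine, would read remains open.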